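A few compounds are considered here, and "the series" means these few. Any claim that something is new, unique, unknown or untested is made for them only; others in the source may bear on it.

Compound 2 `CNCc1cn(S(=O)(=O)c2ncccc2C)c(-c2cccnc2F)c1F` and compound 1 `CNCc1cc(-c2cccnc2F)n(S(=O)(=O)c2cccnc2)c1` are the two compounds measured in a physicochemical assay for lipophilicity, read by HPLC, at pH 7.4; a lower number here means a more polar compound, a higher number a more lipophilic compound. In this assay compound 1 gives -0.85, while compound 2 gives 0.32, the higher of the two numbers and a gap that lies beyond the usual scatter. Compound 3 `CNCc1cn(S(=O)(=O)c2ccc(C)nc2)c(-c2cccnc2F)c1F` has not yet been measured. It differs from compound 2 in one place (6-methylpyridin-3-yl in place of 3-methylpyridin-2-yl on a sulfonyl sulfur). Among the compounds with values here, with no measured pair of this kind to lean on, the expected step of a number 0.12 log units lower from compound 2 to compound 3 (within the scatter) is small and not clearly beyond the scatter. Compound 3 is therefore estimated at 0.2, within -0.3 to 0.7.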

Compound 3, distribution coefficient: 0.62
Beside the measured number, compound 3's estimate is 0.42 log units below it; the measured number falls inside the stated range.
By their numbers in this assay, from the lowest: compound 1; then compounds 2 and 3 (each within the scatter of the next).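

In this assay, 6-methylpyridin-3-yl in place of 3-methylpyridin-2-yl on a sulfonyl sulfur gives a number 0.30 log units higher from compound 2 to compound 3 (within the scatter). This first single-place pair shows that, at this position, these two groups with the same atoms joined differently are not told apart by this measurement. Nothing measured here accounts for the size of this step.

From the compounds shown here alone, whether a plain phenyl group or a group carrying an amine on the sulfonyl sulfur would leave the number within the scatter remains open. So does whether this exchange would give a similar step on the core of compound 1.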